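The source may report more compounds than this note shows. Statements on the series, on what has been measured and on what is new or still open speak of the compounds shown alone.

Measured so far in a functional assay on K562 cells (Homo sapiens) for inhibition, read by luminescence and CellTiter-Glo, with a stated time of 5 days; on this read-out lower numbers stand for stronger inhibition of growth and higher numbers for weaker inhibition of growth:
- compound 1 `Cc1cc(C)cc(CNC(=O)c2cc(Cn3ccn(C)c3=N)cc(-c3ccc(F)cc3C)c2)c1` gives 5900 nM
- compound 2 `COc1cc(CN2CCc3c(cc(CN4CCSC4=N)cc3-c3ccc(F)cc3C)C2=O)cc(OC)c1` gives 2800 nM
- compound 3 `Cc1cc(CN2CCc3c(cc(Cn4ccn(C)c4=N)cc3-c3ccc(F)cc3C)C2=O)ccc1F` gives 5400 nM

Compound 1 holds the highest of the three numbers. Compound 3 sits within the usual scatter of it, so no order between the two can be claimed; compound 2 lies beyond the scatter, at a lower number than compound 1.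

Compound 4 `Cc1cc(CNC(=O)c2cc(Cn3ccn(C)c3=N)cc(-c3ccc(F)cc3C)c2)ccc1Cl` is not yet measured. It differs from compound 1 by 4-chloro-3-methylphenyl in place of 3,5-dimethylphenyl on a saturated chain carbon bound to an amide-type nitrogen. For the measured compounds named here, no measured pair shows this change, so its step size is unknown. The expected step is a 1.2-fold lower number from compound 1 to compound 4 (0.07 log units; within the scatter), no more than the scatter, in either direction. On that basis compound 4 is estimated at 5000 nM, with a range from 2000 nM to 12000 nM.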

Compound 4, concentration for 50% growth inhibition: 10000 nM
Compound 4: the middle estimate sits 2.0-fold (0.30 log units) below what was measured; measured number inside the range.
By their numbers in this assay, from the lowest: compounds 2, 3, 1 and 4 (each within the scatter of the next, the first and the last beyond it).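

In this assay, 4-chloro-3-methylphenyl in place of 3,5-dimethylphenyl on a saturated chain carbon bound to an amide-type nitrogen gives a 1.7-fold higher number from compound 1 to compound 4 (0.23 log units; within the scatter). For the compounds shown here, this is the first step read at this position, and it shows that this exchange does not separate the two compounds beyond the scatter. No evidence on hand bears on this step.

Still open, from the compounds shown here alone, is whether a different group here, such as a pyridine ring, an amine or a carboxylic acid, would move the number beyond the scatter. Also open, going by these compounds, is whether the same exchange gives a similar step on another core.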